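This account rests on a few compounds, and the source may have more. Where it says the series, first, only, none or still open, it means among the compounds named here.

Measured compounds:
compound 1 `CNC(=O)c1c(NCC2CCC3(CC2)CC3)nc(C#N)nc1OCCC1CCN(C)CC1`: 2 nM
compound 2 `CN1CCC(CCOc2cc(NCC3CCC4(CC3)CC4)nc(C#N)n2)CC1`: 22 nM

Of the two compounds measured in an assay on isolated protein for inhibition of cathepsin S (Homo sapiens), read by fluorescence (a higher number here means a weaker inhibitor, a lower number a stronger inhibitor), compound 2 has the higher number; the only other, compound 1, lies lower by an 11-fold higher number from compound 1 to compound 2 (1.04 log units; beyond the scatter). Within the data shown here, that step, hydrogen in place of methylcarbamoyl on an aromatic carbon, is the single measured change that touches the ring carbon now at issue. Compound 3 `CN1CCC(CCOc2nc(C#N)nc(NCC3CCC4(CC3)CC4)c2Br)CC1` carries bromo in place of hydrogen on an aromatic carbon, so the same carbon that stands bare in compound 2 now holds a bromine. Whether a bromo gives back what the methylcarbamoyl gave is not shown; the one measured step on this carbon shows only that leaving it bare costs a large amount. A moderate gain in potency is therefore the expectation. Compound 3 is expected to give 8 nM in this assay, with a likely range from 3 nM to 25 nM. The resulting step is expected to be a 2.8-fold lower number from compound 2 to compound 3 (0.44 log units; beyond the scatter).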

Compound 3, half-maximal inhibitory concentration: 2 nM
Estimate against measurement, compound 3: 4.0-fold (0.60 log units) above; the whole stated range lies above it.
By their numbers in this assay, from the lowest: compounds 1 and 3 (each within the scatter of the next); then compound 2.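

With an 11-fold lower number from compound 2 to compound 3 (1.04 log units; beyond the scatter) in this assay, a single bromine on this aromatic carbon, para to a cyano group, makes a large difference, even though it adds only one heavy atom. Replacing the methylcarbamoyl with bromo gives no change at the digits printed from compound 1 to compound 3 (within the scatter), so the much smaller bromo serves as well as the methylcarbamoyl at this position, and the two compounds cannot be told apart in this measurement. Nothing available explains how a bromine matches the methylcarbamoyl here.

From the compounds shown here alone, whether a chlorine, a fluorine, a methyl or an amine on the same carbon would do as well as bromo remains open. Going by these compounds, how compound 3 behaves on any enzyme other than cathepsin S also stays open.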